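The source may report more compounds than this note shows. Statements on the series, on what has been measured and on what is new or still open speak of the compounds shown alone.

- Compound 1 `COc1ccc(-c2nc3cc[nH]cc-3n2)c(OC)c1`: 0.3 mg/kg
- Compound 2 `COc1cc(SC)ccc1-c1nc2cc[nH]cc-2n1`: 0.2 mg/kg

In a functional assay on the whole organism with Canis familiaris (Canis lupus familiaris) as the target (on this read-out higher numbers stand for an effect only at larger amounts of compound and lower numbers for an effect already at smaller amounts), compound 2 has just one measured neighbour and cannot be told apart from it: a 1.5-fold lower number from compound 1 to compound 2 (0.18 log units; within the scatter). That step exchanged the group on the same aromatic carbon that changes next. Compound 3 `COc1cc([N+](=O)[O-])ccc1-c1nc2cc[nH]cc-2n1` differs from compound 2 by nitro in place of methylsulfanyl on an aromatic carbon. Among the measured compounds shown here, no compound carrying nitro has been measured here, so this single small step offers only weak guidance. In this assay, the expected step stays within the scatter, leaning slightly towards a higher number: a 1.5-fold higher number from compound 2 to compound 3 (0.18 log units; within the scatter). Compound 3 is estimated at 0.3 mg/kg, with an expected range of 0.08 mg/kg to 1.2 mg/kg.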

Compound 3, dose for half-maximal effect: 0.015 mg/kg
Estimate against measurement, compound 3: 20-fold (1.30 log units) above, outside the stated range (below it).
By their numbers in this assay, from the lowest: compound 3; then compounds 2 and 1 (each within the scatter of the next).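

Methoxy and methylsulfanyl on this aromatic carbon could not be told apart, but nitro stands clearly apart from both in this assay: a 13-fold lower number from compound 2 to compound 3 (1.12 log units; beyond the scatter), and a 20-fold lower number from compound 1 to compound 3 (1.30 log units; beyond the scatter). This aromatic carbon therefore responds strongly to the group it carries, which the first two compounds could not show. Nothing measured on these compounds says why the number falls with nitro.

From the compounds shown here alone, whether such a low number is special to nitro remains open, since an amine or a carboxylic acid on the same carbon could give a different answer. Also open, going by these compounds, is whether nitro would have the same effect without the methoxy group on the ring.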